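Triazole series: alkyl chain extension and tolerated concentration

This account rests on a few compounds, and the source may have more. Where it says the series, first, only, none or still open, it means among the compounds named here.

Compound 2 `CC[C@@H](CCn1cncn1)c1ccc(OC)cc1`: 115 ug/mL
Compound 1 `CC[C@@H](CCn1cncn1)c1ccc(Cl)cc1`: 55.3 ug/mL

In an ADME assay on RD cells (Homo sapiens) for cytotoxicity, read by MTT assay, with a stated time of 3 days (a higher number here means that more compound is tolerated, a lower number that less compound is tolerated), compound 2 gives the higher of the two numbers; the nearest is compound 1, whose step to compound 2 reads a 2.1-fold higher number from compound 1 to compound 2 (0.32 log units; beyond the scatter). Compound 3 `CCCC[C@@H](CCn1cncn1)c1ccc(OC)cc1` differs from compound 2 by ethyl in place of hydrogen on a saturated chain carbon, three bonds along the chain from an aromatic carbon. Among the compounds with values here, no measured step touches the saturated chain; the single known step concerns the aromatic substituent and says nothing about this change. The expectation for compound 3 in this assay is therefore a step of no more than the scatter, a 1.3-fold lower number from compound 2 to compound 3 (0.11 log units; within the scatter). Compound 3 is estimated at 90 ug/mL, within 40 ug/mL to 200 ug/mL.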

Compound 3, half-maximal cytotoxic concentration: 39.4 ug/mL
For compound 3 the middle estimate is 2.3-fold (0.36 log units) above the measured one; the measured number lies below the stated range.
By their numbers in this assay, from the lowest: compounds 3 and 1 (each within the scatter of the next); then compound 2.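

The saturated chain carbon, three bonds along the chain from an aromatic carbon, proves sensitive to substitution: in this assay, ethyl in place of hydrogen gives a 2.9-fold lower number from compound 2 to compound 3 (0.47 log units; beyond the scatter), so a change away from the aromatic substituent also moves the tolerated concentration beyond the scatter. No available evidence accounts for this step.

Still open, on these data alone, is whether a longer chain, such as hexyl, at this carbon continues the same direction. Also open, as far as these compounds go, is whether an amine or a carboxylic acid on the chain would give a different result, and whether the ethyl step holds with chloro on the aromatic carbon.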